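The source may hold more compounds than are shown below. What is called first, only, known or untested is meant among the compounds shown, and "the series" means these compounds.

This account follows a series of anilide sulfides sharing one core, in which a methoxyphenyl amide is joined through a sulfur bridge to a nitrophenyl group. Compound 1, `COc1ccccc1NC(=O)c1cc([N+](=O)[O-])ccc1Sc1ccc([N+](=O)[O-])cc1`, carries a nitro group on the amide-bearing ring; compound 2, `COc1ccccc1NC(=O)c1cc(F)ccc1Sc1ccc([N+](=O)[O-])cc1`, carries a fluorine at the same position; compound 3, `COc1ccccc1NC(=O)c1ccccc1Sc1ccc([N+](=O)[O-])cc1`, carries only hydrogen there. In an ADME assay on H9 cells (Homo sapiens) for cytotoxicity, read by MTT assay, with a stated time of 7 days (on this read-out lower numbers stand for higher toxicity in this test and higher numbers for lower toxicity in this test), compound 2 gives 502000 nM. In this assay compound 1 gives "not determined" (no result reported). In this assay compound 3 gives "not determined" (no result reported), so compound 3 stands without a number of its own, and only the value of compound 2 gives any sense of where this core lies on the read-out.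

The step under study leads from compound 3 to compound 4, `COc1ccccc1NC(=O)c1cc(N(C)C)ccc1Sc1ccc([N+](=O)[O-])cc1`. The change is dimethylamino in place of hydrogen on an aromatic carbon. Among the compounds with values here, since no measured pair in this assay shows a comparable change, the size of the step cannot be drawn from the data; the author expects at most a modest shift towards higher toxicity, which may well remain within the scatter of the measurement. On that basis the half-maximal cytotoxic concentration of compound 4 is estimated at 250000 nM, with a plausible range from 60000 nM to 700000 nM.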

Compound 4, half-maximal cytotoxic concentration: 182000 nM
For compound 4 the middle estimate is 1.4-fold (0.14 log units) above the measured one; the range from low to high includes it.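

Within the data shown here, with a second number now available for the aromatic carbon para to the (4-nitrophenyl)sulfanyl group, this assay shows for the first time that this position responds to what it carries: dimethylamino in place of fluoro brings a 2.8-fold lower number from compound 2 to compound 4 (0.44 log units; beyond the scatter) and so moves the series modestly towards higher toxicity in this test. As far as these compounds go, the steps that would start from hydrogen or from nitro cannot be read, as compound 1 and compound 3 have no number of their own, so the effect of dimethylamino relative to the unsubstituted carbon remains unknown and this single comparison of fluoro with dimethylamino is all the position offers. Nothing measured here accounts for the shift, and its cause stays unexplained.

The compounds shown leave open whether a primary amine or a carboxylic acid on this same carbon would give a number closer to that of fluoro or to that of dimethylamino. They also leave open whether diethylamino, with longer chains on the nitrogen, or a pyrrolidine ring in place of the two methyl groups would carry the shift further or reverse it.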